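The source may hold more compounds than are shown below. What is called first, only, known or untested is meant among the compounds shown, and "the series" means these compounds.

Among the measured compounds shown here, in a physicochemical assay for lipophilicity, read by HPLC, using the shake flask method, measured as octanol-water partition, at pH 7.4 (on this read-out lower numbers stand for lower lipophilicity and higher numbers for higher lipophilicity), compound 1 (`Cc1cc2ncccc2cc1Nc1ncc2c(n1)n(C1CCN(C)CC1)c(=O)n2C`) gives 1.8, the higher of the two numbers measured so far. Compound 2 (`Cc1cc2nnccc2cc1Nc1ncc2c(n1)n(C1CCN(C)CC1)c(=O)n2C`) gives 1.2, which lies lower by more than the usual scatter of repeated measurements. Compound 3 (`Cc1cc2ncccc2cc1Nc1ncc2c(n1)n([C@H]1CCN(C3COC3)C1)c(=O)n2C`) keeps the core of compound 1 but carries 1-(oxetan-3-yl)pyrrolidin-3-yl in place of 1-methylpiperidin-4-yl on an aromatic nitrogen of a five-membered aromatic ring with 2 nitrogen: 1-(oxetan-3-yl)pyrrolidin-3-yl in place of 1-methylpiperidin-4-yl on an aromatic nitrogen. For the measured compounds named here, no measured pair differs in one place only, so the data give no direct guide to this exchange, and the expectation in this assay starts from compound 1 at 1.8. A modest upward step is expected, though one that may stay close to the scatter, estimated as a number 0.40 log units higher from compound 1 to compound 3 (beyond the scatter). Compound 3 is therefore expected to read about 2.2, with an estimated range from 1.7 to 2.8.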

Compound 3, distribution coefficient: 1.5
Compound 3: middle estimate off by 0.70 log units, on the high side, and the stated range ends above it.
By their numbers in this assay, from the lowest: compounds 2, 3 and 1 (each within the scatter of the next, the first and the last beyond it).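

In this assay, among the compounds shown here, placing 1-(oxetan-3-yl)pyrrolidin-3-yl on the aromatic nitrogen in place of 1-methylpiperidin-4-yl gives the first step that can be read at this position, a number 0.30 log units lower from compound 1 to compound 3 (within the scatter), so the reading does not separate the two groups. For the compounds shown here, this position thus takes a larger group with two rings and an added oxygen, and the number stays within the scatter of the one for the 1-methylpiperidin-4-yl compound. Nothing measured here gives a reason for this result.

The ring and the oxetan-3-yl group change together in this one step, and the compounds shown leave open what each contributes on its own. On these data alone, a 1-methylpyrrolidin-3-yl group or a 1-(oxetan-3-yl)piperidin-4-yl group on the same nitrogen would pull the two apart, and the opposite stereocentre also remains open.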